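Taking one fluorine off a phenyl ring in two series

This account rests on a few compounds, and the source may have more. Where it says the series, first, only, none or still open, it means among the compounds named here.

Compound 1 `Cc1nc(-c2ccccc2F)c(C(=O)N2CCN(c3cc(Cl)cc(Cl)c3)CC2)o1` and compound 2 `Cc1nc(-c2ccccc2)c(C(=O)N2CCN(c3cc(Cl)cc(Cl)c3)CC2)o1` share one core; compound 3 `COc1cc(OC)cc(N2CCN(C(=O)c3oc(C)nc3-c3cccc(F)c3)CC2)c1` and compound 4 `COc1cc(OC)cc(N2CCN(C(=O)c3oc(C)nc3-c3ccccc3)CC2)c1` share another. How the core of compound 1 and the core of compound 3 differ is not broken down here. In an ADME assay on microsomes from liver (Mus musculus) for metabolic stability, read by LC-MS, with a stated time of 1 h, tested at 5 uM (a lower number here means that less of the compound is left, a higher number that more of the compound is left), compound 1 gives 49% and compound 2 gives 43.4%. Between them the change is hydrogen in place of fluoro on an aromatic carbon, and it made a step of a number 5.6 percentage points lower from compound 1 to compound 2 (within the scatter). Compound 3 gives 11.6% in this assay, the lowest of the three numbers, with compound 2 nearest and beyond the scatter above it.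

Compound 4 has not yet been measured in this assay. It differs from compound 3 by hydrogen in place of fluoro on an aromatic carbon. The surroundings are not identical: in compound 1 the fluoro sits ortho to a large group, in compound 3 it sits meta to a large group, so this is the same kind of change rather than the same change. Going by the values given here, the only guide is the earlier pair, and it moved little. A step of a number 1.6 percentage points lower from compound 3 to compound 4 (within the scatter) is expected, because the earlier step of this kind was a number 5.6 percentage points lower from compound 1 to compound 2 (within the scatter). Compound 4 is therefore expected to give about 10% in this assay, with an estimated range from 3% to 25%, staying near the low value of its parent rather than climbing toward compound 1 or compound 2.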

Compound 4, percent of the compound remaining: 0.7%
Beside the measured number, compound 4's estimate is 9.3 percentage points above it; measured number below the stated range.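

Set side by side in this assay, the two removals of fluoro do not differ by more than the usual scatter allows: the same change on two cores in this assay, a number 5.6 percentage points lower (within the scatter) from compound 1 to compound 2 and a number 10.9 percentage points lower (beyond the scatter) from compound 3 to compound 4, 5.3 percentage points apart, within the scatter of two such steps. The change can therefore be carried from one core to the other with a similar size on this evidence, although only a number 10.9 percentage points lower from compound 3 to compound 4 (beyond the scatter) stands clear of the scatter by itself, and this does not make a general rule: it rests on two pairs, and the fluoro does not leave from the same place on the ring in both. The change in the group on the ring nitrogen, 3,5-dimethoxyphenyl in place of 3,5-dichlorophenyl on an amine nitrogen in a ring, goes with a far larger move, a number 42.7 percentage points lower from compound 2 to compound 4 (beyond the scatter), so in this pair that swap counts for much more than either removal of fluoro.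

The compounds shown leave open whether chloro, methyl or a nitrile in the place of the fluoro would move the number as hydrogen does. They also leave open how a phenyl carrying one methoxy and one chloro on the amine nitrogen would stand between the two cores.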